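Removing a fluoro group from a weakly binding compound

The compounds below may be only part of what the source reports. "The series", "measured", "known", "first", "only" and "open" are said of these compounds alone.

So far, three compounds have been measured in an assay on HEK293 cells for displacement of a labelled ligand from Melanocortin receptor 4 (Homo sapiens); on this read-out lower numbers stand for stronger inhibition and higher numbers for weaker inhibition. Compound 1 `Cc1ccc(N2CCN(C(=O)[C@@H]3CN(C4CCOCC4)C[C@H]3c3ccc(Cl)cc3)CC2)c([C@@H](NC(=O)CN)C(C)C)c1` gives 2 nM in this assay, and compound 2 `CNCC(=O)N[C@H](c1cc(C)ccc1N1CCN(C(=O)[C@@H]2CN(C3CCOCC3)C[C@H]2c2ccc(Cl)cc2)CC1)C(C)C` gives 2.1 nM. These two differ in a single place, a methyl in place of hydrogen on an amine nitrogen, and the step of a 1.1-fold higher number from compound 1 to compound 2 (0.02 log units; within the scatter) lies within the scatter. Compound 3 `CC(C)[C@H](NC(=O)CCN(C)C)c1cccc(F)c1N1CCN(C(=O)[C@@H]2CN(C(C)C)C[C@H]2c2ccc(F)c(Cl)c2)CC1` stands apart: in this assay compound 3 gives 260 nM, the highest of the three numbers, and it differs from them in several places at once.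

Compound 4 `CC(C)[C@H](NC(=O)CCN(C)C)c1cccc(F)c1N1CCN(C(=O)[C@@H]2CN(C(C)C)C[C@H]2c2cccc(Cl)c2)CC1` is the next step from compound 3. The change is hydrogen in place of fluoro on an aromatic carbon: on the aromatic carbon ortho to a chloro group, a hydrogen takes the place of the fluoro, so a 3-chloro-4-fluorophenyl becomes a 3-chlorophenyl. Among the compounds with values here, none of the measured steps concerns an aromatic fluoro, so no direct guide exists; the single measured step, a methyl on an amine, was within the scatter. Losing one small atom on a ring far from the amide and piperazine parts is expected to shift this assay little. The estimated step of a 1.2-fold higher number from compound 3 to compound 4 (0.06 log units; within the scatter) is therefore expected to stay within the scatter, and compound 4 is expected to give about 300 nM, between 120 nM and 750 nM.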

Compound 4, inhibition constant: 370 nM
Compound 4: middle estimate off by 1.2-fold (0.09 log units), on the low side; the range from low to high includes it.
By their numbers in this assay, from the lowest: compounds 1 and 2 (each within the scatter of the next); then compounds 3 and 4 (each within the scatter of the next).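

In this assay, within the data shown here, the step reads a 1.4-fold higher number from compound 3 to compound 4 (0.15 log units; within the scatter) and is the first measured change on this ring, where the earlier single step concerned an amine nitrogen. It shows that on this aromatic carbon, ortho to a chloro group, fluoro and hydrogen cannot be told apart in this read-out, at least on the background of compound 3, so the 3-chloro-4-fluorophenyl and the 3-chlorophenyl serve alike here. No measurement on hand gives a reason for this result.

The compounds shown leave open whether a larger group on the same carbon, such as a methoxy, a trifluoromethyl or an amine, would also pass unnoticed. They also leave open whether the same swap would read the same way on the core of compound 1.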